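Swapping an Ester for a Urea on the Naphthalene Sulfonamide

The compounds below may be only part of what the source reports. "The series", "measured", "known", "first", "only" and "open" are said of these compounds alone.

Compound 2 `CCOC(=O)N1CCC(NS(=O)(=O)c2ccc(OC(=O)c3ccccc3)c3ccccc23)CC1` is the stronger of the two measured compounds: in an assay on L1.2 cells for binding affinity to C-C chemokine receptor type 8 (Homo sapiens) (on this read-out higher numbers stand for weaker inhibition and lower numbers for stronger inhibition), compound 2 gives 16.4 nM, while compound 1 `CCOC(=O)N1CCC(NS(=O)(=O)c2ccc(NCc3ccccc3)c3ccccc23)CC1` gives 45.6 nM. Among the compounds with values here, the only measured step, a 2.8-fold lower number from compound 1 to compound 2 (0.44 log units; beyond the scatter), shows that changing the group at this position can shift the number modestly. Compound 3 `CCOC(=O)N1CCC(NS(=O)(=O)c2ccc(NC(=O)N3CCCCC3)c3ccccc23)CC1` differs from compound 2 by ((piperidin-1-yl)carbonyl)amino in place of benzoyloxy on an aromatic carbon. Within the data shown here, with no measured step involving this urea-type group, only a small shift is expected, most likely toward a slightly higher number. Compound 3 is therefore expected to give 30 nM, with a range from 10 nM to 90 nM. This expected change amounts to a 1.8-fold higher number from compound 2 to compound 3 (0.26 log units; within the scatter).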

Compound 3, inhibition constant: 126 nM
For compound 3 the middle estimate is 4.2-fold (0.62 log units) below the measured one; the whole stated range lies below it.
By their numbers in this assay, from the lowest: compound 2; then compound 1; then compound 3.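

In this assay the ((piperidin-1-yl)carbonyl)amino group gives the weakest binding of the three compounds, with a 7.7-fold higher number from compound 2 to compound 3 (0.89 log units; beyond the scatter) on leaving benzoyloxy. Keeping a nitrogen on the aromatic ring does not hold the number: (piperidin-1-yl)carbonyl in place of benzyl on that nitrogen gives a 2.8-fold higher number from compound 1 to compound 3 (0.44 log units; beyond the scatter) and shows that what the nitrogen carries counts. Nothing available explains either shift. Still open, as far as these compounds go, is whether a simple acetamide or a carboxylic acid on this aromatic carbon would bring the number back toward that of compound 2.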